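Aryl variation at the saturated ring carbon of the shared core

The source may hold more compounds than are shown below. What is called first, only, known or untested is meant among the compounds shown, and "the series" means these compounds.

Going by the values given here, compound 1 `N#CC1=C(N)OC(c2c[nH]c3ccccc23)=C(C#N)C1c1ccccc1` is the only member of the set with a number in a functional assay, tested at 50 ug/mL; a lower number here means a weaker effect, a higher number a stronger effect of the compound at the concentration tested; there compound 1 gives 14.4%. In this assay compound 2 `N#CC1=C(N)OC(c2c[nH]c3ccccc23)=C(C#N)C1c1ccccc1F` is reported only as "not active" (no number reported), without a number. Compound 3 `COc1ccc(C2C(C#N)=C(N)OC(c3c[nH]c4ccccc34)=C2C#N)cc1OC` differs from compound 1 by 3,4-dimethoxyphenyl in place of phenyl on a saturated ring carbon. Among the compounds with values here, no step between measured compounds is at hand, so the size of this change cannot be read from the set; a step within the usual scatter, or a modest decrease, is expected. The step from compound 1 to compound 3 is estimated as a number 3.4 percentage points lower from compound 1 to compound 3 (within the scatter). Compound 3 is expected to give 11% in this assay, within 0% to 26%.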

Compound 3, a percentage reported as activity, at one concentration (the size of the read-out at that concentration, not a potency): 14.5%
For compound 3 the middle estimate is 3.5 percentage points below the measured one, and the stated range covers the measured number.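

In this assay, 3,4-dimethoxyphenyl on the saturated ring carbon gives a number 0.1 percentage points higher from compound 1 to compound 3 (within the scatter), so this position holds a substituted aryl group with two methoxy groups and no difference from phenyl can be told apart. The step to compound 2 cannot be read, as that compound carries no number. Nothing at hand explains this result. On these data alone, it stays open whether an aryl group carrying an amine or a carboxylic acid at this carbon would separate from compound 1. As far as these compounds go, a cyclohexyl group in place of the aryl ring is equally open.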